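Swapping a Sulfonamide for an Ester on a Biaryl

This account rests on a few compounds, and the source may have more. Where it says the series, first, only, none or still open, it means among the compounds named here.

The three measured compounds share a biaryl arrangement and are compared in an assay on COS-7 cells for inhibition of patatin-like phospholipase domain-containing protein 2 (Mus musculus), tested at 200 uM; a higher number here means more inhibition at the concentration tested (going by the name of the read-out), a lower number less inhibition. Compound 1, `CCOC(=O)c1cccc(-c2ccsc2)c1`, gives 67%. Compound 2, `CCOC(=O)c1cccc(-c2ccc(CN3CCN(S(C)(=O)=O)CC3)o2)c1`, gives 66%. Compound 3, `CCOc1ccc(-c2cccc(S(=O)(=O)NC)c2)cc1`, gives 47%, the lowest of the three numbers; its gap to compound 2 and its gap to compound 1 both lie beyond the usual scatter of such measurements, so compound 3 stands apart from the other two.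

The unmeasured compound 4, `CCCCOC(=O)c1cccc(-c2ccc(OCC)cc2)c1`, is derived from compound 3 by one change: butoxycarbonyl in place of methylsulfamoyl on an aromatic carbon. Compounds 1 and 2, which both carry an ethyl ester in the same kind of position, sit at the higher end of the measured range, and compound 3, which carries the methylsulfamoyl group, sits at the lower end. For the measured compounds named here, no step between two measured compounds isolates this change, so the expectation rests on that comparison alone.

Compound 4 is therefore expected to move upward from compound 3, with an estimated step of a number 15 percentage points higher from compound 3 to compound 4 (beyond the scatter), larger than the scatter but not certain to reach the numbers of compound 1 and compound 2. Compound 4 is estimated at 62%, with a range from 45% to 78%.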

Compound 4, a percentage reported as inhibition, at one concentration (the size of the read-out at that concentration, not a potency): 61%
Estimate against measurement, compound 4: 1 percentage points above, within the range that was stated.
By their numbers in this assay, from the lowest: compound 3; then compounds 4, 2 and 1 (each within the scatter of the next).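

In this assay, butoxycarbonyl in place of methylsulfamoyl on an aromatic carbon, meta to a group of 9 heavy atoms, gives a number 14 percentage points higher from compound 3 to compound 4 (beyond the scatter). For the compounds shown here, this is the first reading of the exchange with the rest of the structure held constant, whereas the earlier compounds differed from one another in more than one place and could not isolate it. The step therefore ties the higher number to this one position and this one change, which swaps a group with 1 hydrogen-bond donor for one with 0 and carries 7 heavy atoms instead of 5, but no measurement at hand gives a reason for the rise.

The single step replaces the whole group, so the compounds shown do not separate the contribution of the carbonyl, the butyl chain or the lost donor. On these data alone, an ethyl ester, a carboxylic acid or a sulfonamide bearing a butyl chain on its nitrogen at this position would begin to pull these apart, and whether the step holds on another core also remains open.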